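Acetamido for Furoate: an Expected Gain in Stability

This account rests on a few compounds, and the source may have more. Where it says the series, first, only, none or still open, it means among the compounds named here.

Of the compounds shown here, two sharing a core have so far been measured in an ADME assay on cells (Hepatocyte, Mus musculus) for metabolic stability, with a stated time of 30 min; on this read-out lower numbers stand for a less stable compound and higher numbers for a more stable compound. Compound 1 `Nc1cc(C(F)(F)F)cc2c(=O)cc(N3CCN(CC4CCC(O)CC4)CC3)sc12` gives 60% in this assay. Compound 2 `O=C(OC1CCC(CN2CCN(c3cc(=O)c4cc(C(F)(F)F)cc([N+](=O)[O-])c4s3)CC2)CC1)c1ccco1` gives 0.6%, the lowest of the two numbers; its nearest neighbour is compound 1, whose value lies higher by an amount beyond the usual scatter. Within the data shown here, no pair of the measured compounds differs in a single place, so no step between measured compounds can be stated.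

Compound 3 `CC(=O)NC1CCC(CN2CCN(c3cc(=O)c4cc(C(F)(F)F)cc([N+](=O)[O-])c4s3)CC2)CC1` has not yet been measured in this assay. It differs from compound 2 as follows: acetamido in place of ((furan-2-yl)carbonyl)oxy on a saturated ring carbon. An acetamido group thus takes the place of the ((furan-2-yl)carbonyl)oxy group on a saturated ring carbon of a six-membered non-aromatic ring of carbon only.

Among the measured compounds shown here, with no measured single-point step to lean on, the expectation for compound 3 rests on the two values at hand. Compound 3 is expected to give 20%, within a range from 3% to 55%. The expected step of a number 19.4 percentage points higher from compound 2 to compound 3 (beyond the scatter) is upward and beyond the scatter, because compound 1 gives 60% and shows that the shared core can remain largely intact in this assay.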

Compound 3, percent of the compound remaining: 94.9%
Compound 3: middle estimate off by 74.9 percentage points, on the low side; the whole stated range lies below it.
By their numbers in this assay, from the lowest: compound 2; then compound 1; then compound 3.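

In this assay, among these compounds, acetamido in place of ((furan-2-yl)carbonyl)oxy on a saturated ring carbon gives the first single-place comparison in this set, with a number 94.3 percentage points higher from compound 2 to compound 3 (beyond the scatter). It shows that this position, three ring bonds from the ring atom that bears a large group, can by itself carry the read-out from near the bottom of the scale to near its top: with everything else held the same, compound 3 gives 94.9% in this assay, as a group of 8 heavy atoms with a five-membered aromatic ring gives way to one of 4 heavy atoms with no ring and 1 hydrogen-bond donor. Nothing measured in this set bears on why the number moves so far at this position.

The compounds shown leave open whether the gain follows the amide link itself or the loss of the furan ring, a question that a furan-2-carboxamide, a primary amine or a carboxylic acid on the same carbon would help to separate. Going by these compounds, it also remains open whether acetamido would give a similar number on the core of compound 1.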